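The source may hold more compounds than are shown below. What is called first, only, known or untested is meant among the compounds shown, and "the series" means these compounds.

In an ADME assay on BaF3 cells (Mus musculus) for antiproliferative activity (on this read-out lower numbers stand for stronger inhibition of growth and higher numbers for weaker inhibition of growth), compound 1, with the structure `Cc1ccc(NC(=O)c2cccc(C(F)(F)F)c2)cc1OC1CCN(C(=O)c2ccno2)CC1`, gives only a limit of the assay, reading > 10000 nM. Compound 2, with the structure `Cc1ccc(NC(=O)c2cc(Cl)cc(C(F)(F)F)c2)cc1OC1CCN(C(=O)c2cccnc2)CC1`, likewise reaches only a limit in this assay, reading > 10000 nM. Going by the values given here, compound 2 therefore stands where the one other value shown also stands, at the limit described by the limit of > 10000 nM in this assay, at which 2 of the 2 values shown sit. Compound 3, with the structure `Cc1ccc(NC(=O)c2cc(Cl)cc(C(F)(F)F)c2)cc1OC1CCN(C(=O)c2ccno2)CC1`, is the compound not yet measured. It differs from compound 2 by 1,2-oxazol-5-yl in place of pyridin-3-yl on a carbonyl carbon. Among the compounds with values here, compound 1 already carries this 1,2-oxazol-5-yl group on the carbonyl carbon and sits at the limit, and no measured step between compounds tells what this change does in this assay. On this basis compound 3 is expected to remain at or beyond the limit as well, so the step estimated from compound 2 to compound 3 is a step that the limit leaves unreadable from compound 2 to compound 3, not more than the scatter. The estimate for compound 3 in this assay is 20000 nM, expected between 5000 nM and 80000 nM.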

Compound 3, concentration for 50% growth inhibition: > 10000 nM
Compound 3: a limit, no number; the forecaster's own chance of this, stated with the estimate: 80%; the middle value is on the limit's open side.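

Compound 3 also gives only a limit in this assay, so neither the step from compound 1 to compound 3 nor the step from compound 2 to compound 3 can be read: the limit of > 10000 nM in this assay, at which 3 of the 3 values shown sit.

The compounds shown leave open whether either change, chloro in place of hydrogen or 1,2-oxazol-5-yl in place of pyridin-3-yl, alters growth inhibition at all.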